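The compounds below may be only part of what the source reports. "The series", "measured", "known", "first", "only" and "open" are said of these compounds alone.

Compound 2 `COc1ccc(/C=C\c2cc(OC)c(OC)c(OC)c2)cc1OCc1ccc(CN2CC[C@H](O)C2)cc1` holds the only number shown in an ADME assay on NCM460 cells (Homo sapiens) for cytotoxicity, read by CCK-8 assay, with a stated time of 48 h; on this read-out higher numbers stand for weaker inhibition and lower numbers for stronger inhibition: compound 2 gives 51000 nM. Compound 1 `COc1ccc(/C=C\c2cc(OC)c(OC)c(OC)c2)cc1OCc1ccc(CN2CCCCC2C(=O)O)cc1` in this assay gives > 50000 nM, a limit of the assay and not a number. The step from compound 1 to compound 2 reads a step that the limit leaves unreadable from compound 1 to compound 2, so its size is not readable. Compound 3 `COc1ccc(/C=C\c2cc(OC)c(OC)c(OC)c2)cc1OCc1ccc(CN2CCCC[C@@H]2C(=O)O)cc1` differs from compound 2 by 2-carboxypiperidin-1-yl in place of 3-hydroxypyrrolidin-1-yl on a saturated chain carbon bound to an aromatic carbon. Among the compounds with values here, no measured step in this assay is readable, and the only bearing evidence is the limit of > 50000 nM in this assay, at which 1 of the 2 values shown sits, which concerns compound 1 and carries the same 2-carboxypiperidin-1-yl. Compound 3 is expected, on the strength of the limit of > 50000 nM in this assay, at which 1 of the 2 values shown sits, to sit at the limit, a step of a 1.2-fold higher number from compound 2 to compound 3 (0.07 log units; within the scatter), with an estimate of 60000 nM ranging from 30000 nM to 150000 nM.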

Compound 3, half-maximal inhibitory concentration: > 50000 nM
Compound 3 gave a limit, no number (the forecaster's own chance of this, stated with the estimate: 70%); the middle value lies beyond the limit too.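

In this assay compound 3 gives > 50000 nM, a limit and not a number. Within the data shown here, no step among compound 1, compound 2 and compound 3 can be read. Still open, as far as these compounds go, is how far compound 1 and compound 3 lie from compound 2, and whether the defined configuration of compound 3 matters.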